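Trading 4-methylphenyl for 3,4-dichlorophenyl in compound 4

The source may report more compounds than this note shows. Statements on the series, on what has been measured and on what is new or still open speak of the compounds shown alone.

Of the compounds shown here, three sharing one core have been tested in a functional assay on T-24 cells (Homo sapiens) for antiproliferative activity, read by MTT assay, with a stated time of 48 h; a higher number here means a weaker inhibitor, a lower number a stronger inhibitor. Compound 1 `Cc1ccc(NC(=O)Nc2cccc(CNc3nccnc3Cl)c2)cc1` gives 9820 nM. Compound 2 `Cc1ccc(NC(=O)Nc2cccc(CNc3nccnc3Cl)c2)cc1Cl` gives 7390 nM. Compound 3 `O=C(Nc1cccc(CNc2nccnc2Cl)c1)NC1CCCC1` reaches only a limit of the assay, > 40000 nM, as noted in the limit of > 40000 nM in this assay, at which 1 of the 3 values shown sits.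

Among the two real numbers compound 1 holds the higher one, with compound 2 nearest: the step of a 1.3-fold lower number from compound 1 to compound 2 (0.12 log units; within the scatter) lies within the scatter, so no order between them can be claimed. The steps of an at least 4.0-fold higher number from compound 1 to compound 3 (0.60 log units; beyond the scatter) and an at least 5.4-fold higher number from compound 2 to compound 3 (0.73 log units; beyond the scatter) are beyond the scatter and show that the aromatic group on the amide-type nitrogen matters.

Compound 4 `O=C(Nc1cccc(CNc2nccnc2Cl)c1)Nc1ccc(Cl)c(Cl)c1` is not yet measured. It differs from compound 1 by 3,4-dichlorophenyl in place of 4-methylphenyl on an amide-type nitrogen. The step from compound 1 to compound 2 bears most on this change, since it also adds chloro to an aromatic carbon and stayed within the scatter; the steps to compound 3 matter less, as compound 4 keeps an aryl group on that nitrogen.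

For compound 4 a step of a 1.6-fold lower number from compound 1 to compound 4 (0.21 log units; within the scatter) is therefore expected, at most a small gain. Compound 4 is estimated at 6000 nM, within a range from 2500 nM to 15000 nM.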

Compound 4, half-maximal inhibitory concentration: 5210 nM
The estimate for compound 4 lay 1.2-fold (0.06 log units) above the measured number, within the range that was stated.
By their numbers in this assay, from the lowest: compounds 4, 2 and 1 (each within the scatter of the next). At a limit, above all of these: compound 3.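

Set against the 4-methylphenyl of compound 1, the 3,4-dichlorophenyl group on the amide-type nitrogen gives a 1.9-fold lower number from compound 1 to compound 4 (0.28 log units; within the scatter), and chloro in place of methyl on an aromatic carbon gives a 1.4-fold lower number from compound 2 to compound 4 (0.15 log units; within the scatter), so in this assay compound 1, compound 2 and compound 4 cannot be put in order, and this position accepts a phenyl ring with two chlorine atoms and no methyl without a change that stands clear of the scatter. The gap between an aromatic ring and cyclopentyl on this nitrogen, seen before with compound 1 and compound 2, now holds for a third aromatic group, as an at least 7.6-fold lower number from compound 3 to compound 4 (0.88 log units; beyond the scatter) shows. That step rests on a limit of the assay for compound 3 rather than on a true number: the limit of > 40000 nM in this assay, at which 1 of the 4 values shown sits.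

The groups on the phenyl ring shown so far are only methyl and chloro, so it remains open whether a methoxy group, a trifluoromethyl group or an amine there would shift the number beyond the scatter. On these data alone, it is also open how a longer chain or a carboxylic acid on the amide-type nitrogen would fare in this assay.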